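Swapping the benzimidazole for a phenoxymethyl arm

The source may hold more compounds than are shown below. What is called first, only, known or untested is meant among the compounds shown, and "the series" means these compounds.

Three compounds share a core carrying a 4-aminopiperidin-1-yl group and a second aryl ring, and differ in one further arm. Compound 1 `Cc1cc(C)cc(CNc2cncc(-c3cc(C)cc(C)c3)c2N2CCC(N)CC2)c1` has a (3,5-dimethylbenzyl)amino arm and gives 0.8 nM in a functional assay on CHO-K1 cells for agonist activity at somatostatin receptor type 2 (Homo sapiens), read by cAMP accumulation, with a stated time of 30 min; a higher number here means that more compound is needed for the effect, a lower number that less compound is needed. Compound 2 `Cc1cc(C)cc(-c2cncc(-c3nc4cc(F)ccc4[nH]3)c2N2CCC(N)CC2)c1` carries a 5-fluoro-1H-benzimidazol-2-yl arm and gives 0.013 nM, the lowest of the three numbers. Compound 3 `NC1CCN(c2c(-c3cc(F)cc(Cl)c3)cncc2-c2nc3cc(F)ccc3[nH]2)CC1` keeps that arm but bears a 3-chloro-5-fluorophenyl ring in place of the 3,5-dimethylphenyl and gives 0.081 nM.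

The step of a 62-fold lower number from compound 1 to compound 2 (1.79 log units; beyond the scatter) shows that the benzimidazole arm is the main source of the low number for compound 2, and a 6.2-fold higher number from compound 2 to compound 3 (0.79 log units; beyond the scatter) shows that changing the other ring moves the number much less.

Compound 4 `Cc1cc(C)cc(OCc2cncc(-c3cc(C)cc(C)c3)c2N2CCC(N)CC2)c1` is compound 2 with (3,5-dimethylphenoxy)methyl in place of 5-fluoro-1H-benzimidazol-2-yl on an aromatic carbon. Among the compounds with values here, this returns to an arm built like the one in compound 1: a 3,5-dimethyl-substituted ring held by a one-atom linker and a methylene, with the benzimidazole gone. Because the step of a 62-fold lower number from compound 1 to compound 2 (1.79 log units; beyond the scatter) was large, removing that arm again is expected to undo most of it, so compound 4 should land near compound 1 rather than near compound 2, a step of about a 62-fold higher number from compound 2 to compound 4 (1.79 log units; beyond the scatter). The estimate for compound 4 is 0.8 nM, within a range from 0.2 nM to 3 nM.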

Compound 4, half-maximal effective concentration: 3.7 nM
Compound 4: middle estimate off by 4.6-fold (0.67 log units), on the low side; the measured number lies above the stated range.
By their numbers in this assay, from the lowest: compound 2; then compound 3; then compound 1; then compound 4.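

Placing (3,5-dimethylphenoxy)methyl on the aromatic carbon ortho to the 4-aminopiperidin-1-yl group gives a 280-fold higher number from compound 2 to compound 4 (2.45 log units; beyond the scatter) in this assay, so the low number of compound 2 does not follow from the size of the arm alone, since both groups count 10 heavy atoms. The two arms that end in a 3,5-dimethyl-substituted ring also differ from each other, with a 4.6-fold higher number from compound 1 to compound 4 (0.67 log units; beyond the scatter), which shows that the way this ring is joined to the core changes the number, though far less than losing the 5-fluoro-1H-benzimidazol-2-yl group does. No measurement available here explains either step.

The compounds shown leave open which part of the 5-fluoro-1H-benzimidazol-2-yl arm matters most: its five-membered aromatic ring, its six-membered aromatic ring or its fluorine. A 1H-imidazol-2-yl group or a 1H-benzimidazol-2-yl group without fluorine at this position would begin to separate these parts, while the effect of a 3-chloro-5-fluorophenyl ring alongside either of the 3,5-dimethyl-substituted arms also remains an open question.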